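The source may report more compounds than this note shows. Statements on the series, on what has been measured and on what is new or still open speak of the compounds shown alone.

Notes on the aryl-triazole series. The shared core carries a 3-methylphenyl in compound 1 `Cc1cccc(-n2nncc2CN2C(=O)C3(C(C#N)=C(N)Oc4c3c3nc5ccccc5nc3c3ccccc43)c3ccccc32)c1`, which in a functional assay on A549 cells (Homo sapiens) for antiproliferative activity, read by MTT assay, with a stated time of 48 h (a higher number here means a weaker inhibitor, a lower number a stronger inhibitor), gives 39600 nM. Compound 2 `N#CC1=C(N)Oc2c(c3nc4ccccc4nc3c3ccccc23)C12C(=O)N(Cc1cnnn1-c1ccc(Br)cc1)c1ccccc12` carries a 4-bromophenyl and in this assay gives 44300 nM. Compound 3 `N#CC1=C(N)Oc2c(c3nc4ccccc4nc3c3ccccc23)C12C(=O)N(Cc1cnnn1-c1ccccc1Br)c1ccccc12` carries a 2-bromophenyl. Among the measured compounds shown here, for compound 3 this assay reports only a limit, > 50000 nM, so compound 3 stands among the three as the one without a number of its own; see (the limit of > 50000 nM in this assay, at which 1 of the 3 values shown sits). The step of a 1.1-fold higher number from compound 1 to compound 2 (0.05 log units; within the scatter), the step of an at least 1.2-fold higher number from compound 1 to compound 3 (0.10 log units; that floor lies within the scatter) and the step of an at least 1.1-fold higher number from compound 2 to compound 3 (0.05 log units; that floor lies within the scatter) all fall within the scatter, so the three aryl groups on the aromatic nitrogen give closely similar readings here. Compound 4 `N#CC1=C(N)Oc2c(c3nc4ccccc4nc3c3ccccc23)C12C(=O)N(Cc1cnnn1-c1ccc([N+](=O)[O-])cc1)c1ccccc12` differs from compound 3 by 4-nitrophenyl in place of 2-bromophenyl on an aromatic nitrogen. All three measured steps bear on this change, since each swaps the aryl group on the same aromatic nitrogen, and none moved the number beyond the scatter. The expected step of an at least 1.0-fold lower number from compound 3 to compound 4 (0.01 log units; that floor lies within the scatter) is therefore none beyond the scatter. Compound 4 is thus estimated at 48000 nM, between 25000 nM and 100000 nM, with a fair chance that this assay again reports only a limit.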

Compound 4, half-maximal inhibitory concentration: > 50000 nM
Compound 4 ended at the assay's limit; the forecaster's own chance of this, stated with the estimate: 50%; middle value at least 1.0-fold (0.01 log units) away from the limit.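

Compound 4 in this assay gives only a limit, > 50000 nM, and a second aryl group on this aromatic nitrogen now sits at that limit: the limit of > 50000 nM in this assay, at which 2 of the 4 values shown sit.

Nitro in place of bromo on the aromatic carbon gives an at least 1.1-fold higher number from compound 2 to compound 4 (0.05 log units; that floor lies within the scatter), and 4-nitrophenyl in place of 3-methylphenyl gives an at least 1.2-fold higher number from compound 1 to compound 4 (0.10 log units; that floor lies within the scatter), so a group carrying hydrogen-bond acceptors still shows no step beyond the scatter at this position. The step between compound 3 and compound 4 cannot be read, as both stand at limits.

As far as these compounds go, how far past the limit compound 3 and compound 4 lie stays open, so no order among the four aryl groups can be given. From the compounds shown here alone, whether an amine or a carboxylic acid on the phenyl ring, or a longer chain in place of it, would move the number also stays open.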